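Lengthening the chain from propyl to butyl

A few compounds are considered here, and "the series" means these few. Any claim that something is new, unique, unknown or untested is made for them only; others in the source may bear on it.

Compound 1 `CCn1ccnc1-c1cc(OC)c(OC)c(OC)c1`: > 100000 nM
Compound 2 `CCCn1ccnc1-c1cc(OC)c(OC)c(OC)c1`: > 100000 nM
Compound 3 `COc1cc(-c2nccn2C(C)C)cc(OC)c1OC`: > 100000 nM

All three entries are limits, not numbers. In a functional assay on MDA-MB-231 cells (Homo sapiens) for antiproliferative activity, read by MTT assay, with a stated time of 72 h (on this read-out higher numbers stand for weaker inhibition and lower numbers for stronger inhibition), compound 2 stands at > 100000 nM, which is a limit. Compound 4 `CCCCn1ccnc1-c1cc(OC)c(OC)c(OC)c1` changes one place: methyl in place of hydrogen on a saturated chain carbon, three bonds along the chain from an aromatic nitrogen. This turns propyl into butyl. The closest measured change of this kind is a step that the two limits leave unreadable from compound 1 to compound 2. Two further steps bear on it, a step that the two limits leave unreadable from compound 1 to compound 3 and a step that the two limits leave unreadable from compound 2 to compound 3, and neither gives a size. All three compounds sit at the limit of > 100000 nM in this assay, at which 3 of the 3 values shown sit. With no measured size to build on, the expected result in this assay is a number no higher from compound 2 to compound 4 (the limit leaves the size open), meaning no change beyond the scatter in either direction. The estimate for compound 4 is 100000 nM, with an expected range from 50000 nM to 200000 nM.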

Compound 4, half-maximal inhibitory concentration: 70400 nM
The estimate for compound 4 lay 1.4-fold (0.15 log units) above the measured number; the measured number falls inside the stated range.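

Compound 4 is the only one of the four with a number rather than a limit in this assay, so butyl at this position gives steps with a readable floor: an at least 1.4-fold lower number from compound 2 to compound 4 (0.15 log units; that floor lies within the scatter), an at least 1.4-fold lower number from compound 3 to compound 4 (0.15 log units; that floor lies within the scatter) and an at least 1.4-fold lower number from compound 1 to compound 4 (0.15 log units; that floor lies within the scatter). Each floor lies within the scatter, so these steps alone do not establish a real gain from the added methyl. The steps among the other three compounds cannot be read: the limit of > 100000 nM in this assay, at which 3 of the 4 values shown sit.

Going by these compounds, the true size of all three steps remains open. So does whether a longer chain, such as pentyl, or an amine at the chain end would give a lower number.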